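A few compounds are considered here, and "the series" means these few. Any claim that something is new, unique, unknown or untested is made for them only; others in the source may bear on it.

Working notes on a short amide series sharing one core, compared for solubility in a physicochemical assay for solubility, read by nephelometry, at pH 2; a lower number here means a less soluble compound, a higher number a more soluble compound. Compound 1 `Cc1cnc(NC(=O)CCCOc2cncc(Cl)c2)s1` gives 1600 nM. Compound 3 `Cc1cnc(NC(=O)CCCOc2cccc(Cl)n2)s1` returns only a limit of the assay, < 1200 nM, as the limit of < 1200 nM in this assay, at which 1 of the 3 values shown sits, records. Compound 2 `N#Cc1cnc(NC(=O)CCCOc2cccc(C(F)(F)F)c2)s1` likewise returns only a limit, < 1600 nM, as the limit of < 1600 nM in this assay, at which 1 of the 3 values shown sits, records, so compound 2 cannot be ranked against the other two. Compound 4 `N#Cc1cnc(NC(=O)CCCOc2ccccc2)s1` awaits measurement in this assay. The change from compound 2 to compound 4 is hydrogen in place of trifluoromethyl on an aromatic carbon. Going by the values given here, no measured pair differs in a single place, so no step size is established; a modest gain in solubility in this assay, possibly within the scatter, is expected. Compound 4 is expected to give 2500 nM (range 1000 nM to 6000 nM). The expected step is therefore an at least 1.5-fold higher number from compound 2 to compound 4 (0.19 log units; that floor lies within the scatter).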

Compound 4, solubility: 1100 nM
Compound 4: middle estimate off by 2.3-fold (0.36 log units), on the high side; measured number inside the range.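

Going by these compounds alone, compound 2 gives only a limit of the assay, < 1600 nM, so no step to compound 4 can be read in this assay. The compounds shown leave open what hydrogen in place of trifluoromethyl on an aromatic carbon does to this read-out.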